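The source may report more compounds than this note shows. Statements on the series, on what has been measured and on what is new or still open speak of the compounds shown alone.

Compound 1 `CCn1c(C(C)NS(=O)(=O)c2ccc(Cl)cc2)nc2cnccc21`: 35 mL.min-1.g-1
Compound 2 `CCn1c([C@@H](C)NS(=O)(=O)C2CC2)nc2ccc(C(F)(F)F)cc21`: < 3 mL.min-1.g-1

In an ADME assay (liver) for metabolic stability, with Liver microsome (Homo sapiens) as the target, read by LC-MS, using microsomes and NADPH, with a stated time of 5 min, at 37 degrees C (a lower number here means slower removal, a higher number faster removal of the compound), compound 1 gives 35 mL.min-1.g-1. Compound 2 gives < 3 mL.min-1.g-1 in this assay, and this is a limit of the assay rather than a number, so compound 2 stands at the limit of < 3 mL.min-1.g-1 in this assay, at which 1 of the 2 values shown sits. Compound 3 `CCn1c([C@@H](C)NS(=O)(=O)c2c(F)cc(F)cc2F)nc2ccc(C(F)(F)F)cc21` has not yet been measured. It differs from compound 2 by 2,4,6-trifluorophenyl in place of cyclopropyl on a sulfonyl sulfur. Among the measured compounds shown here, no step between measured compounds covers this change, so the expectation rests on the change alone: a modest rise, beyond the scatter, is expected. Compound 3 is therefore expected to give 8 mL.min-1.g-1 in this assay, within 3 mL.min-1.g-1 to 25 mL.min-1.g-1. The expected step from compound 2 to compound 3 is an at least 2.6-fold higher number from compound 2 to compound 3 (0.42 log units; beyond the scatter).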

Compound 3, intrinsic clearance in microsomes: 19 mL.min-1.g-1
For compound 3 the middle estimate is 2.4-fold (0.38 log units) below the measured one, within the range that was stated.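

On a sulfonyl sulfur whose other neighbour is the sulfonamide nitrogen, 2,4,6-trifluorophenyl in place of cyclopropyl gives an at least 6.3-fold higher number from compound 2 to compound 3 (0.80 log units; beyond the scatter) in this assay. This is the first pair shown to differ in one place only, and it shows that the group on this sulfur changes the reading. Compound 2 stands at a limit of the assay, not a number, so the step has only a lower bound: the limit of < 3 mL.min-1.g-1 in this assay, at which 1 of the 3 values shown sits.

The compounds shown leave open whether the rise follows the aromatic ring itself or its fluorine atoms, which a plain phenyl on the same sulfur would separate. Going by these compounds, how an amine or a longer alkyl chain there would read in this assay also stays open.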